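The source may report more compounds than this note shows. Statements on the series, on what has been measured and on what is new or still open speak of the compounds shown alone.

Compound 2 `COc1ccc(Nc2ccc3c(c2)C(=O)N(C2CCC(=O)NC2=O)C3=O)cc1` carries a methoxy where compound 1 `CCCCCc1ccc(Nc2ccc3c(c2)C(=O)N(C2CCC(=O)NC2=O)C3=O)cc1` carries a pentyl. Among the compounds with values here, in an assay on FRT-Jurkat cells for inhibition of nuclear factor NF-kappa-B complex (Homo sapiens), read by flow cytometry, with a stated time of 24 h, tested at 10 uM (a higher number here means more inhibition at the concentration tested (going by the name of the read-out), a lower number less inhibition), compound 2 gives 29%, the highest of the two numbers so far; compound 1 gives 12%. Within the data shown here, the one measured step, a number 17 percentage points higher from compound 1 to compound 2 (beyond the scatter), is the only guide here. Compound 3 `CCc1ccc(Nc2ccc3c(c2)C(=O)N(C2CCC(=O)NC2=O)C3=O)cc1` differs from compound 2 by ethyl in place of methoxy on an aromatic carbon. This change runs back toward an alkyl substituent, though ethyl rather than pentyl, so a decrease is expected, possibly smaller than the measured step. The estimate for compound 3 is 18%, between 5% and 32%. The expected step is a number 11 percentage points lower from compound 2 to compound 3 (beyond the scatter).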

Compound 3, a percentage reported as inhibition, at one concentration (the size of the read-out at that concentration, not a potency): 5%
Beside the measured number, compound 3's estimate is 13 percentage points above it; the measured number falls inside the stated range.
By their numbers in this assay, from the lowest: compounds 3 and 1 (each within the scatter of the next); then compound 2.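

In this assay, ethyl in place of methoxy on the aromatic carbon para to a large group gives a number 24 percentage points lower from compound 2 to compound 3 (beyond the scatter) and so the shorter alkyl group does not keep the level of compound 2. Ethyl in place of pentyl gives a number 7 percentage points lower from compound 1 to compound 3 (within the scatter) and so these two chain lengths are not told apart, with only the methoxy compound standing clear of both. No measurement here explains the difference between methoxy and the alkyl groups.

On these data alone, whether the oxygen itself matters remains open. An ethoxy, a hydroxyl or an amine at this position would bear on that.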